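Bromo for methoxy on the aryl arm of the core

The source may hold more compounds than are shown below. What is called first, only, known or untested is meant among the compounds shown, and "the series" means these compounds.

Measured so far:
compound 1 `COc1ccc(-c2cn3ccnc3c(-c3ccc4ncn(C5CCCCC5)c4c3)n2)cc1`: 87.2%
compound 2 `O=Cc1ccc(-c2cn3ccnc3c(-c3ccc4ncn(C5CCCCC5)c4c3)n2)cc1`: 37.4%
compound 3 `Clc1ccc(-c2cn3ccnc3c(-c3ccc4ncn(C5CCCCC5)c4c3)n2)cc1`: 11.1%

In a functional assay on NCI/ADR-RES cells (Homo sapiens) for inhibition, read by sulforhodamine B assay, with a stated time of 48 h, tested at 10 uM (a higher number here means more inhibition at the concentration tested (going by the name of the read-out), a lower number less inhibition), compound 1 stands highest of the three numbers. Its nearest neighbour is compound 2, reached by a number 49.8 percentage points lower from compound 1 to compound 2 (beyond the scatter); the furthest is compound 3, reached by a number 76.1 percentage points lower from compound 1 to compound 3 (beyond the scatter). Between those two, the step of a number 26.3 percentage points lower from compound 2 to compound 3 (beyond the scatter) is the smaller one.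

Compound 4 `Brc1ccc(-c2cn3ccnc3c(-c3ccc4ncn(C5CCCCC5)c4c3)n2)cc1` is not yet measured. It differs from compound 1 by bromo in place of methoxy on an aromatic carbon.

The step that bears most directly on this change is the one with chloro in place of methoxy, a number 76.1 percentage points lower from compound 1 to compound 3 (beyond the scatter), a large fall. The formyl case, a number 49.8 percentage points lower from compound 1 to compound 2 (beyond the scatter), also fell, though less far. Both replacements of the methoxy on this ring have lowered the read-out well beyond the scatter. On that basis a large downward step is expected for compound 4, of about a number 72.2 percentage points lower from compound 1 to compound 4 (beyond the scatter) in this assay, landing near the chloro compound.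

Compound 4 is therefore estimated to give 15% in this assay, with a range from 0% to 45%.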

Compound 4, a percentage reported as inhibition, at one concentration (the size of the read-out at that concentration, not a potency): 30.5%
Compound 4: middle estimate off by 15.5 percentage points, on the low side; low and high end bracket the measured number.
By their numbers in this assay, from the lowest: compound 3; then compounds 4 and 2 (each within the scatter of the next); then compound 1.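

In this assay, the bromo replacement also loses much of the read-out, a number 56.7 percentage points lower from compound 1 to compound 4 (beyond the scatter), so all three replacements of methoxy at this position tested so far fall well beyond the scatter. The two halogens do not read alike, with a number 19.4 percentage points higher from compound 3 to compound 4 (beyond the scatter), so the chloro result does not stand in for bromo here. Bromo and formyl cannot be told apart, at a number 6.9 percentage points lower from compound 2 to compound 4 (within the scatter), which leaves compound 3 alone at the bottom of the set and compound 1 alone at the top.

Whether the high read-out is specific to methoxy stays open, since no hydroxy, ethoxy or dimethylamino group on this aromatic carbon appears among these compounds. Nothing available explains the gap between methoxy and the other three groups, or the one between chloro and bromo.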